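The compounds below may be only part of what the source reports. "The series", "measured", "known", "first", "only" and "open" are said of these compounds alone.

Compound 3 `O=S(=O)(Nc1ccc2oc(-c3ccccc3)nc2c1)c1ccccc1F` is one of three measured members of this series. In an assay on cells for inhibition of HSP60/HSP10 (Homo sapiens), with a stated time of 60 min (on this read-out lower numbers stand for stronger inhibition and higher numbers for weaker inhibition), compound 3 gives > 100000 nM, which is a limit of the assay and not a number. Compound 1 `Cc1ccccc1S(=O)(=O)Nc1ccc2oc(-c3ccccc3)nc2c1` carries a methyl in place of the fluoro on the same aromatic carbon. In this assay compound 1 gives > 100000 nM, likewise a limit. The step that the two limits leave unreadable from compound 1 to compound 3 is therefore unreadable, as both values sit at the limit of > 100000 nM in this assay, at which 2 of the 3 values shown sit. Within the data shown here, compound 2 `O=S(=O)(Nc1ccc(-c2nc3cc(NS(=O)(=O)c4cccc(O)c4)ccc3o2)cc1)c1cccc(O)c1`, in which a 3-hydroxyphenyl group stands on each sulfonyl sulfur, is the only compound with a number: in this assay compound 2 gives 17000 nM. Among the measured compounds shown here, no step between compound 2 and compound 4 is given, so its value shows only that a 3-hydroxyphenyl sulfonamide can fall within the measured range.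

Compound 4 `O=S(=O)(Nc1ccc2oc(-c3ccccc3)nc2c1)c1cccc(O)c1` differs from compound 3 by 3-hydroxyphenyl in place of 2-fluorophenyl on a sulfonyl sulfur. No measured step directly bears on this change, since the only step shown, from compound 1 to compound 3, is unreadable. The estimate thus rests on compound 2 alone. Compound 4 is expected to give about 60000 nM, with a range from 15000 nM to 200000 nM. The step of an at least 1.6-fold lower number from compound 3 to compound 4 (0.22 log units; that floor lies within the scatter) is expected to move compound 4 toward the measured range, though a limit remains a real possibility.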

Compound 4, half-maximal inhibitory concentration: 76000 nM
Estimate against measurement, compound 4: 1.3-fold (0.10 log units) below, within the range that was stated.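

Replacing 2-fluorophenyl with 3-hydroxyphenyl on the sulfonyl sulfur gives the singly substituted core its first number rather than a limit in this assay, with an at least 1.3-fold lower number from compound 3 to compound 4 (0.11 log units; that floor lies within the scatter). Replacing 2-methylphenyl in the same place gives an at least 1.3-fold lower number from compound 1 to compound 4 (0.11 log units; that floor lies within the scatter), and since both floors lie within the scatter, neither step alone establishes a real change or fixes its true size. Among these compounds, the link to the doubly substituted compound is readable, with hydrogen in place of ((3-hydroxyphenyl)sulfonyl)amino on an aromatic carbon giving a 4.5-fold higher number from compound 2 to compound 4 (0.65 log units; beyond the scatter), so this second sulfonamide arm is worth a modest step beyond the scatter, one that the earlier compounds could not show.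

On these data alone, how far the 2-fluorophenyl and 2-methylphenyl compounds lie from compound 4 remains unknown, as their values are still limits: the limit of > 100000 nM in this assay, at which 2 of the 4 values shown sit. It also remains open whether the hydroxy group itself accounts for the number, as the compounds shown do not include an unsubstituted phenyl, a methoxy group, an amine or a carboxylic acid on that ring.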